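Fluoro on the outer phenyl of compound 3

A few compounds are considered here, and "the series" means these few. Any claim that something is new, unique, unknown or untested is made for them only; others in the source may bear on it.

Measured compounds:
compound 1 `O=C(NO)c1cccc(OCc2ccc(-c3cccnc3)cc2)c1`, 52300 nM
compound 2 `COc1ccc(C(=O)NO)cc1OCc1ccc(-c2cccnc2)cc1`, 4970 nM
compound 3 `O=C(NO)c1cccc(OCc2ccc(-c3noc(-c4ccccc4)n3)cc2)c1`, > 100000 nM

Compound 1 `O=C(NO)c1cccc(OCc2ccc(-c3cccnc3)cc2)c1` is the parent of the series; in an assay on isolated protein for inhibition of sphingomyelin phosphodiesterase (Homo sapiens), read by fluorescence, with a stated time of 30 min (on this read-out higher numbers stand for weaker inhibition and lower numbers for stronger inhibition), compound 1 gives 52300 nM. Compound 2 `COc1ccc(C(=O)NO)cc1OCc1ccc(-c2cccnc2)cc1` carries a methoxy on the core, and in this assay compound 2 gives 4970 nM; the change is an 11-fold lower number from compound 1 to compound 2 (1.02 log units; beyond the scatter). Compound 3 `O=C(NO)c1cccc(OCc2ccc(-c3noc(-c4ccccc4)n3)cc2)c1` exchanges the pyridyl for a phenyl-substituted oxadiazole. For compound 3 this assay reports only a limit, > 100000 nM, so compound 3 stands at the weak end of the numbers shown (the limit of > 100000 nM in this assay, at which 1 of the 3 values shown sits).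

Compound 4 `O=C(NO)c1cccc(OCc2ccc(-c3noc(-c4cccc(F)c4)n3)cc2)c1` differs from compound 3 by fluoro in place of hydrogen on an aromatic carbon. Going by the values given here, no measured step touches this outer phenyl; the only step known, from methoxy on the core, concerns another place and does not bear on a fluoro here. The expectation is therefore no step beyond the scatter in this assay, and compound 4 is expected to stay near the limit, with an estimated a number no higher from compound 3 to compound 4 (the limit leaves the size open). For compound 4 in this assay the estimate is 100000 nM, between 30000 nM and 300000 nM.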

Compound 4, half-maximal inhibitory concentration: > 100000 nM
Compound 4 gave a limit, no number; the forecaster's own chance of this, stated with the estimate: 70%; the middle value lies on the limit itself.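

In this assay compound 4 gives > 100000 nM as a limit. Going by these compounds alone, compound 3 also stands at a limit, so no step between compound 3 and compound 4 can be read: the limit of > 100000 nM in this assay, at which 2 of the 4 values shown sit. On these data alone, whether fluoro on the outer phenyl changes inhibition at all stays open.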